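Cytotoxicity of compound 3: from butoxy to benzyloxy

A few compounds are considered here, and "the series" means these few. Any claim that something is new, unique, unknown or untested is made for them only; others in the source may bear on it.

Compound 1 `CCOc1ccc(/C=N/NC(N)=S)c2ccccc12`: in a toxicity assay on MRC5 cells (Homo sapiens) for cytotoxicity, read by MTT assay, with a stated time of 72 h (on this read-out lower numbers stand for an effect already at smaller amounts and higher numbers for an effect only at larger amounts of compound), compound 1 gives > 200000 nM, a limit of the assay.
Compound 2 `CCCCOc1ccc(/C=N/NC(N)=S)c2ccccc12`: in this assay compound 2 gives 41000 nM.

For the measured compounds named here, compound 2 holds the only number here; the other value is a limit (the limit of > 200000 nM in this assay, at which 1 of the 2 values shown sits). Compound 3 `NC(=S)N/N=C/c1ccc(OCc2ccccc2)c2ccccc12` differs from compound 2 by phenyl in place of propyl on a saturated chain carbon bound to an oxygen on an aromatic ring. Going by the values given here, the only measured step, an at least 4.8-fold lower number from compound 1 to compound 2 (0.68 log units; beyond the scatter), is an enlargement on the same chain and gave a lower number. A lower number is therefore expected here too, with the step estimated at about a 2.1-fold lower number from compound 2 to compound 3 (0.31 log units; beyond the scatter). Compound 3 is estimated at 20000 nM, expected between 5000 nM and 80000 nM.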

Compound 3, half-maximal effective concentration: 29000 nM
For compound 3 the middle estimate is 1.5-fold (0.16 log units) below the measured one, within the range that was stated.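

In this assay, butoxy to benzyloxy gives a 1.4-fold lower number from compound 2 to compound 3 (0.15 log units; within the scatter), so at this position the phenyl ring and the open propyl end cannot be told apart. Phenyl in place of methyl gives an at least 6.8-fold lower number from compound 1 to compound 3 (0.83 log units; beyond the scatter), which shows that the ring, like the longer chain, goes with a measurable number in this assay. Compound 1 holds a limit rather than a number, so this step has only one fixed end: the limit of > 200000 nM in this assay, at which 1 of the 3 values shown sits.

The compounds shown leave open how a longer chain than butyl, or an amine or a carboxylic acid on this chain, would read. They also leave open how a phenyl ring carrying a further group would read.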